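From 3-Methoxyphenyl to 2-Fluorophenyl on a Shared Core

The source may hold more compounds than are shown below. What is called first, only, known or untested is meant among the compounds shown, and "the series" means these compounds.

In an ADME assay on THP-1 cells (Homo sapiens) for cytotoxicity, read by flow cytometry and propidium iodide staining, with a stated time of 72 h (on this read-out higher numbers stand for weaker inhibition and lower numbers for stronger inhibition), compound 1 (`CC(=O)Nc1ccc2oc(-c3ccccc3F)c(O)c(=O)c2c1`) gives 47000 nM, compound 2 (`COc1ccccc1-c1oc2ccc(NC(C)=O)cc2c(=O)c1OC`) gives 108000 nM and compound 3 (`COc1cccc(-c2oc3ccc(NC(C)=O)cc3c(=O)c2OC)c1`) gives 5000 nM. Compound 3 therefore has the lowest of the three numbers, and its gaps to the other two lie beyond the scatter. The next compound is compound 4 (`COc1c(-c2ccccc2F)oc2ccc(NC(C)=O)cc2c1=O`), which carries 2-fluorophenyl in place of 3-methoxyphenyl on an aromatic carbon. The new group sits next to the ring oxygen and ortho to a methoxy group.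

Among the compounds with values here, one measured step bears directly on this change: a 22-fold lower number from compound 2 to compound 3 (1.33 log units; beyond the scatter). This large step replaced 2-methoxyphenyl with 3-methoxyphenyl. The change to compound 4 also leaves 3-methoxyphenyl for a group named with a 2, so the number should rise, although fluoro is not methoxy and the guide is only rough. Compound 1, which also carries 2-fluorophenyl, gives 47000 nM, although it differs elsewhere from compound 4. A large move towards weaker inhibition is therefore expected, and the estimated change in this assay is a 9.0-fold higher number from compound 3 to compound 4 (0.95 log units; beyond the scatter). For compound 4 the expected value is 45000 nM, with an estimated range from 14000 nM to 120000 nM.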

Compound 4, half-maximal inhibitory concentration: > 125000 nM
Compound 4: only a limit was reported; the forecaster's own chance of this, stated with the estimate: 10%; middle value at least 2.7-fold (0.44 log units) from the limit.
By their numbers in this assay, from the lowest: compound 3; then compound 1; then compound 2. At a limit, above all of these: compound 4.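

Compound 4 gives a limit of the assay and not a number, so each step to it in this assay marks only a floor: the limit of > 125000 nM in this assay, at which 1 of the 4 values shown sits. At this position, next to the ring oxygen, the swap of 3-methoxyphenyl for 2-fluorophenyl gives an at least 25-fold higher number from compound 3 to compound 4 (1.39 log units; beyond the scatter), and the change on the neighbouring oxygen, methyl in place of hydrogen on an oxygen on an aromatic ring, gives an at least 2.6-fold higher number from compound 1 to compound 4 (0.42 log units; beyond the scatter), so with 2-fluorophenyl held fixed, that methyl does not bring the number down. Between the two groups named with a 2, fluoro in place of methoxy gives an at least 1.1-fold higher number from compound 2 to compound 4 (0.06 log units; that floor lies within the scatter), and since that floor lies within the scatter, no order can be stated for this pair.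

The step from compound 3 to compound 4 changes both the substituent and where it sits on the phenyl ring, so the compounds shown cannot say how much of the large step belongs to each. A 3-fluorophenyl group would separate the two, while an unsubstituted phenyl or a 3-aminophenyl group at the same position would show whether the low number of compound 3 depends on methoxy itself.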